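This account rests on a few compounds, and the source may have more. Where it says the series, first, only, none or still open, it means among the compounds named here.

Working notes on the stilbene pair.

For the measured compounds named here, compound 1 `Fc1ccc(/C=C/c2cc(F)cc(F)c2)cc1` and compound 2 `CCCCOc1ccc(/C=C/c2cc(OC)cc(OC)c2)cc1` are the two measured members. In an assay on cytosol from liver for antagonist activity at aryl hydrocarbon receptor (Oryctolagus cuniculus) (a higher number here means a weaker inhibitor, a lower number a stronger inhibitor), compound 1 gives 3.8 nM. In this assay compound 2 gives 20 nM, the higher of the two numbers; the gap between compound 2 and compound 1 lies beyond the usual scatter, so compound 2 is the weaker inhibitor of the two. Going by the values given here, the two compounds differ in several places at once, and no single step between them is worked out, so nothing about any one group can be read from that pair.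

Compound 3 `CCCCOc1ccc(/C=C\c2cc(OC)cc(OC)c2)cc1` has not yet been measured. Relative to compound 2 the difference is the two compounds have the same atoms and bonds and differ only in configuration as drawn: 1 of 1 stereo elements differ; a double bond is drawn E in compound 2 and Z in compound 3: the two compounds have the same atoms and bonds and differ only in configuration as drawn, the double bond being E in compound 2 and Z in compound 3. Among the compounds with values here, no measured pair in this set shows what such a change does here, so the size of the step rests on the change alone. A step toward a higher number, beyond the scatter, is expected: a 4.0-fold higher number from compound 2 to compound 3 (0.60 log units; beyond the scatter). Compound 3 is accordingly estimated at 80 nM, with a range from 20 nM to 400 nM.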

Compound 3, inhibition constant: 43 nM
Estimate against measurement, compound 3: 1.9-fold (0.27 log units) above; low and high end bracket the measured number.
By their numbers in this assay, from the lowest: compound 1; then compound 2; then compound 3.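

The double bond is now the one place with a read step: in this assay, turning it from E to Z gives a modest loss (a 2.2-fold higher number from compound 2 to compound 3 (0.33 log units; beyond the scatter)). Unlike the pair of compound 1 and compound 2, which differ in several places at once, this pair allows a single change to be read, and the step can be assigned to configuration alone because nothing else separates the two structures: the fact that compounds 2 and 3 differ only in the configuration as drawn. The change weakens inhibition without removing it, as compound 3 still gives 43 nM, so on this substitution pattern the E form is favoured, but it is not required for nanomolar inhibition.

On these data alone, whether a step of this size and direction holds for the fluorine-bearing stilbene of compound 1 remains open, since this one pair cannot show how the configuration effect depends on the ring substituents. Also open, as far as these compounds go, is how either configuration responds when the methoxy groups give way to hydroxyl groups or an amine, or when the butyl chain gives way to a longer chain.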